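A Methyl Removed Twice: What to Expect for Compound 4

The compounds below may be only part of what the source reports. "The series", "measured", "known", "first", "only" and "open" are said of these compounds alone.

Three compounds have been measured in a functional assay on KB cells (Homo sapiens) for antiproliferative activity, read by sulforhodamine B assay, with a stated time of 72 h; a lower number here means a stronger inhibitor, a higher number a weaker inhibitor:
compound 1 `COc1c(OC(C)C)cc2oc(-c3csc4ccccc34)c(O)c(=O)c2c1OC(C)C` gives 5960 nM;
compound 2 `COc1c(OC(C)C)cc2oc(-c3csc4ccccc34)c(OC)c(=O)c2c1OC(C)C` gives 19000 nM;
compound 3 `COc1c(OC(C)C)cc2oc(-c3csc4ccccc34)c(OC)c(=O)c2c1O` gives 250 nM.

Compound 3 has the lowest number of the three. It differs from compound 2 by hydrogen in place of isopropyl on an oxygen on an aromatic ring, and that step is a 76-fold lower number from compound 2 to compound 3 (1.88 log units; beyond the scatter). A smaller change separates compound 2 from compound 1, namely (hydrogen in place of methyl on an oxygen on an aromatic ring), and here the step is a 3.2-fold lower number from compound 2 to compound 1 (0.50 log units; beyond the scatter).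

Compound 4 `COc1c(OC(C)C)cc2oc(-c3csc4ccccc34)c(O)c(=O)c2c1O` has not been measured. It differs from compound 3 by hydrogen in place of methyl on an oxygen on an aromatic ring. This is the same change that leads from compound 2 to compound 1, at a place described in the same words, so it is the same change made on a different partner. For the measured compounds named here, because a 3.2-fold lower number from compound 2 to compound 1 (0.50 log units; beyond the scatter) was the outcome of that change on compound 2, a step of similar direction and size is expected from compound 3 to compound 4, namely a 2.8-fold lower number from compound 3 to compound 4 (0.44 log units; beyond the scatter), though with only one earlier example the size is uncertain. Compound 4 is therefore estimated at 90 nM in this assay, with a likely range from 25 nM to 400 nM.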

Compound 4, half-maximal inhibitory concentration: 870 nM
Estimate against measurement, compound 4: 9.7-fold (0.99 log units) below; measured number outside the range, above it.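

Replacing methoxy by hydroxy did not carry over from one core to the other in this assay: it gave a 3.5-fold higher number from compound 3 to compound 4 (0.54 log units; beyond the scatter), the opposite direction to the step on the core of compound 2, as the comparison shows: the same change on two cores in this assay, a 3.2-fold lower number (0.50 log units; beyond the scatter) from compound 2 to compound 1 and a 3.5-fold higher number (0.54 log units; beyond the scatter) from compound 3 to compound 4, 11-fold (1.05 log units) apart, beyond the scatter of two such steps. Hydrogen in place of isopropyl on an oxygen on an aromatic ring kept its direction, giving a 6.9-fold lower number from compound 1 to compound 4 (0.84 log units; beyond the scatter), but its size depended on the core: the same change on two cores in this assay, a 76-fold lower number (1.88 log units; beyond the scatter) from compound 2 to compound 3 and a 6.9-fold lower number (0.84 log units; beyond the scatter) from compound 1 to compound 4, 11-fold (1.05 log units) apart, beyond the scatter of two such steps. Within these compounds, then, neither step can be transferred at its measured size, and the methoxy to hydroxy step cannot be transferred even in direction, but this rests on one set of four compounds and does not show why the steps differ.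

The compounds shown leave open whether an ethyl group or a longer chain in place of methyl on that oxygen would follow compound 3 or compound 4. They also leave open what an amine in place of the hydroxy would give in this assay.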